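The compounds below may be only part of what the source reports. "The series", "measured", "known", "first", "only" and "open" are said of these compounds alone.

Series notes. Compound 1, `COc1ccc(C2N=C(SCc3ccccc3)NC(C)=C2C(=O)Nc2ccc(F)cc2)cc1OC`, and compound 2, `COc1ccc(C2N=C(SCc3ccccc3Cl)NC(C)=C2C(=O)Nc2ccc(F)cc2)cc1OC`, share one core; compound 3, `CC1=C(C(=O)Nc2ccc([N+](=O)[O-])cc2)C(c2ccc(Br)cc2)N=C(SCc2ccccc2)N1`, and the unmeasured compound 4, `CC1=C(C(=O)Nc2ccc([N+](=O)[O-])cc2)C(c2ccc(Br)cc2)N=C(SCc2ccccc2Cl)N1`, share another. The difference between the two cores is not broken down here. In a functional assay on the whole organism (artery, strain albino) with Rattus norvegicus as the target, with a stated time of 15 min, at a dose of 10 mg/kg by the oral route (on this read-out lower numbers stand for less inhibition and higher numbers for more inhibition at the one dose given (going by the name of the read-out)), compound 1 gives 1.5%. Compound 2 differs from compound 1 by chloro in place of hydrogen on an aromatic carbon and in this assay compound 2 gives 2.6%, which makes a number 1.1 percentage points higher from compound 1 to compound 2 (within the scatter). Compound 3 gives 2.1% in this assay; its number stands within the scatter of both compound 1 and compound 2, so no order among the three measured compounds can be read. All three sit at the low end of the read-out at the single oral dose given.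

Compound 4 differs from compound 3 by chloro in place of hydrogen on an aromatic carbon. The place of the incoming group is described in the same words for both pairs, so this is the same change as that from compound 1 to compound 2, now made on the core of compound 3. For the measured compounds named here, nothing among the measured compounds indicates that the core of compound 3 responds to this change differently from the core of compound 1. Because the same change earlier gave a number 1.1 percentage points higher from compound 1 to compound 2 (within the scatter), the expected step is a number 0.4 percentage points higher from compound 3 to compound 4 (within the scatter). Compound 4 is therefore estimated at 2.5% in this assay, with an expected range from 0% to 8% that allows for the scatter of single-dose readings.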

Compound 4, a percentage reported as inhibition, in the whole organism at one dose (the size of the read-out at that dose, not a potency): 1.5%
Estimate against measurement, compound 4: 1 percentage points above; the range from low to high includes it.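

On the second core, the change from benzylsulfanyl to (2-chlorobenzyl)sulfanyl comes out in this assay as a number 0.6 percentage points lower from compound 3 to compound 4 (within the scatter). Set beside the step on the first core, the two steps do not differ by more than repeated readings would allow: the same change on two cores in this assay, a number 1.1 percentage points higher (within the scatter) from compound 1 to compound 2 and a number 0.6 percentage points lower (within the scatter) from compound 3 to compound 4, 1.7 percentage points apart, within the scatter of two such steps. This fits the change carrying from one core to the other without a visible difference, but it does not show that the change has a shared size or direction on the two cores, nor that it moves the read-out at all, as each step on its own stays within the scatter and all four compounds sit at the low end of the read-out at the single oral dose.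

The compounds shown leave open whether anything at this part of the molecule moves the read-out, as chloro is the only group here that enters on the benzyl ring, and an amine, a carboxylic acid or a longer chain in place of the benzyl group is not among them. Also open is what the difference between the two cores contributes, as no pair shown separates it into single changes.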